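A few compounds are considered here, and "the series" means these few. Any claim that something is new, unique, unknown or untested is made for them only; others in the source may bear on it.

Measured so far:
Compound 1, `C=C(Br)C(=O)Nc1cccc(/C=C2\SC(=O)N(Cc3ccc(C)cc3)C2=O)c1`: 1000 nM
Compound 2, `CC(C)(C)c1ccc(CN2C(=O)S/C(=C\c3cccc(N)c3)C2=O)cc1`: 188000 nM
Compound 3, `C=C(Br)C(=O)Nc1cccc(/C=C2\SC(=O)N(Cc3ccc(F)cc3)C2=O)c1`: 920 nM

These three compounds share a core and were tested in a functional assay on FM3A cells (Mus musculus) for cytotoxicity, read by cell counting, with a stated time of 2 days; a lower number here means a stronger inhibitor, a higher number a weaker inhibitor. Compound 3 has the lowest of the three numbers. Its nearest neighbour is compound 1, which gives 1000 nM; the step of a 1.1-fold lower number from compound 1 to compound 3 (0.04 log units; within the scatter) lies within the scatter, so the two cannot be told apart. Compound 2 stands far away at 188000 nM, but it differs from compound 3 in more than one place, so nothing can be drawn from it about any single change.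

Compound 4, `C=C(Br)C(=O)Nc1cccc(/C=C2\SC(=O)N(Cc3ccc(C(C)(C)C)cc3)C2=O)c1`, has not yet been measured. It differs from compound 3 by tert-butyl in place of fluoro on an aromatic carbon. Going by the values given here, the only step that bears on this is the one from compound 1 to compound 3, which showed that swapping the group on this aromatic carbon changed nothing beyond the scatter. Compound 2 also carries a tert-butyl group, yet its other difference prevents any conclusion. In this assay compound 4 is therefore expected to show a step of about a 1.1-fold higher number from compound 3 to compound 4 (0.04 log units; within the scatter), that is, none beyond the scatter, with an estimated value of 1000 nM and a range from 400 nM to 2500 nM.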

Compound 4, half-maximal inhibitory concentration: 5200 nM
For compound 4 the middle estimate is 5.2-fold (0.72 log units) below the measured one, outside the stated range (above it).
By their numbers in this assay, from the lowest: compounds 3 and 1 (each within the scatter of the next); then compound 4; then compound 2.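

In this assay, tert-butyl shows that this aromatic carbon does respond to what it carries: replacing fluoro gives a 5.7-fold higher number from compound 3 to compound 4 (0.75 log units; beyond the scatter), and replacing methyl gives a 5.2-fold higher number from compound 1 to compound 4 (0.72 log units; beyond the scatter), although fluoro and methyl themselves could not be told apart. With tert-butyl held in place, adding the (1-bromoethenyl)carbonyl group to the nitrogen gives a 36-fold lower number from compound 2 to compound 4 (1.56 log units; beyond the scatter), a much larger step than either change on the aromatic carbon, so this group still leaves compound 4 far ahead of compound 2 despite the loss seen with tert-butyl. No supporting measurement is available to explain either effect.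

Going by these compounds, three groups on this carbon cannot establish a trend, so the effect of an amine, a methoxy group or a carboxylic acid there remains open. It is also unknown how the compounds would respond if chlorine replaced the bromine in the (1-bromoethenyl)carbonyl group.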